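This account rests on a few compounds, and the source may have more. Where it says the series, first, only, none or still open, it means among the compounds named here.

Measured so far:
- compound 1, `C[C@@H](O)Cc1cc(-c2ccnc3[nH]nc(C(F)(F)F)c23)cc(C2(C#N)CC2)c1`, with 42%
- compound 2, `C[C@H](O)Cc1cc(-c2ccnc3[nH]nc(C(F)(F)F)c23)cc(C2(C#N)CC2)c1`, with 37%

In an ADME assay on S9 fraction from liver (Rattus norvegicus) for metabolic stability, read by LC-MS, using NADPH, with a stated time of 60 min, tested at 10 uM (on this read-out higher numbers stand for a more stable compound and lower numbers for a less stable compound), compound 1 gives 42%, and compound 2 gives 37%. The two numbers lie within the usual scatter of each other, and the step of a number 5 percentage points lower from compound 1 to compound 2 (within the scatter) is the only measured one. It rests on (the fact that compounds 1 and 2 differ only in the configuration as drawn), so it tells how the read-out reacts to a swap of configuration at one carbon and nothing more. Compound 2 thus stands together with compound 1, without a real difference between them.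

Compound 3, `N#CC1(c2cc(CC(O)C3CC3)cc(-c3ccnc4[nH]nc(C(F)(F)F)c34)c2)CC1`, is not yet measured. It keeps the shared core and the configuration of compound 2 and changes one group: cyclopropyl(hydroxy)methyl in place of 1-hydroxyethyl on a saturated chain carbon bound to an aromatic carbon. Going by the values given here, no measured step speaks to a change of this kind, since the single step in hand concerns configuration only and was within the scatter. There is therefore no ground to expect a step in this assay beyond the scatter in either direction. Compound 3 is expected to give about 35%, with a range from 15% to 60%, which means an expected step of a number 2 percentage points lower from compound 2 to compound 3 (within the scatter).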

Compound 3, percent of the compound remaining: 0%
The estimate for compound 3 lay 35 percentage points above the measured number; the whole stated range lies above it.
By their numbers in this assay, from the lowest: compound 3; then compounds 2 and 1 (each within the scatter of the next).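

In this assay, the change from 1-hydroxyethyl to cyclopropyl(hydroxy)methyl on a saturated chain carbon bound to an aromatic carbon brings a number 37 percentage points lower from compound 2 to compound 3 (beyond the scatter), and the same change brings a number 42 percentage points lower from compound 1 to compound 3 (beyond the scatter). Compounds 1 and 2 had shown only that swapping the configuration at one carbon of this chain leaves the read-out within the scatter, whereas compound 3 shows that the stability of these three compounds responds strongly to the group placed here, with compound 3 at 0%. None of the information at hand bears on the cause of this large loss, and the drop itself does not reveal where or how compound 3 is consumed.

As far as these compounds go, it remains open whether the three-membered ring itself matters or whether any group with more carbon atoms would do the same, a question that an open-chain isopropyl or a larger cyclobutyl in place of the cyclopropyl ring could help to answer. From the compounds shown here alone, it also remains open how the read-out would respond if the hydroxy group in this chain were replaced by a methoxy group or a fluorine atom, and whether a single defined configuration of the cyclopropyl compound would behave differently, as compound 3 has no stereocentre defined.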